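This account rests on a few compounds, and the source may have more. Where it says the series, first, only, none or still open, it means among the compounds named here.

Of the compounds shown here, three have so far been tested in a functional assay on HeLa cells for antagonist activity at 5-hydroxytryptamine receptor 6 (Homo sapiens); a lower number here means a stronger inhibitor, a higher number a weaker inhibitor. Compound 1, `Cc1ccc(S(=O)(=O)c2n[nH]c3ccc(N4CCN(C)CC4)cc23)cc1`, gives 112 nM in this assay, which is the highest of the three numbers and therefore marks it as the weakest inhibitor of the group. Compound 2, `CC(C)Cn1nc(S(=O)(=O)c2cccc3ccccc23)c2cc(N3CCN(C)CC3)ccc21`, gives 1.4 nM in this assay, and compound 3, `CCCn1nc(S(=O)(=O)c2cccc3ccccc23)c2cc(N3CCNCC3)ccc21`, gives 2.2 nM in this assay. Both of these numbers sit far below that of compound 1, beyond the usual scatter, but each of these two compounds differs from compound 1 at more than one place, so no single structural change can be credited with the gap.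

Compound 4, `CN1CCN(c2ccc3[nH]nc(S(=O)(=O)c4ccc(F)cc4)c3c2)CC1`, has not yet been measured in this assay. It differs from compound 1 in exactly one place: fluoro in place of methyl on an aromatic carbon. This is an exchange of one small group for another of the same size, with no change in ring count, hydrogen bonding groups or charge. Going by the values given here, no measured pair in this set isolates such a swap, so its effect cannot be read off from the data. The expectation is that the step of a 1.0-fold lower number from compound 1 to compound 4 (0.01 log units; within the scatter) stays within the usual scatter, with no clear direction. Compound 4 is therefore estimated at 110 nM in this assay, with a likely range from 40 nM to 300 nM.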

Compound 4, half-maximal inhibitory concentration: 467 nM
Compound 4: the middle estimate sits 4.2-fold (0.63 log units) below what was measured; the measured number lies above the stated range.
By their numbers in this assay, from the lowest: compounds 2 and 3 (each within the scatter of the next); then compound 1; then compound 4.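

In this assay, going from 4-methylphenyl to 4-fluorophenyl on the shared core gives a 4.2-fold higher number from compound 1 to compound 4 (0.62 log units; beyond the scatter) and so a weaker inhibitor, which shows that this place on the ring, para to a large group, responds to the exchange of a single atom. The two groups match in every count available here: each has one heavy atom, no ring, no hydrogen-bond donors or acceptors and no net charge, so those counts alone do not predict the outcome at this position. No measurement at hand explains why compound 4 is the weaker inhibitor of the pair.

As far as these compounds go, this single pair shows only that methyl is preferred over fluoro here, so it remains open how a plain hydrogen, a chlorine atom, a methoxy group or a longer chain such as ethyl would behave at the same place. Also open is which structural differences account for the much lower numbers of compound 2 and compound 3, since neither differs from compound 1 or compound 4 in only one place.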